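Notes on the anilinopyrimidine-benzothiazole series in MCF7 cells

The source may hold more compounds than are shown below. What is called first, only, known or untested is meant among the compounds shown, and "the series" means these compounds.

Measured so far:
compound 1 `Cc1cnc(Nc2ccc(S(C)(=O)=O)cc2)nc1Nc1nc2ccccc2s1` — 6550 nM
compound 2 `Cc1cnc(Nc2ccc([N+](=O)[O-])cc2)nc1Nc1nc2ccccc2s1` — > 50000 nM
compound 3 `Cc1cnc(Nc2ccc(S(N)(=O)=O)cc2)nc1Nc1nc2ccccc2s1` — > 50000 nM

In a functional assay on MCF7 cells (Homo sapiens) for antiproliferative activity, read by MTT assay, with a stated time of 48 h (a higher number here means a weaker inhibitor, a lower number a stronger inhibitor), compound 1 gives 6550 nM. For compound 2 only a limit of the assay is recorded, > 50000 nM. For compound 3 likewise only a limit, > 50000 nM. Thus compound 2 sits at the limit of > 50000 nM in this assay, at which 2 of the 3 values shown sit, together with compound 3.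

Compound 4 `COc1cccc(Nc2ncc(C)c(Nc3nc4ccccc4s3)n2)c1` differs from compound 2 by 3-methoxyphenyl in place of 4-nitrophenyl on a nitrogen on an aromatic ring. The steps known, an at least 7.6-fold higher number from compound 1 to compound 2 (0.88 log units; beyond the scatter) and an at least 7.6-fold higher number from compound 1 to compound 3 (0.88 log units; beyond the scatter), both touch the sulfonyl or nitro end of the same ring; a step that the two limits leave unreadable from compound 2 to compound 3 is unreadable. For the measured compounds named here, no step touches a methoxy group. Compound 4 is therefore expected near the limit, with a step of an at least 2.5-fold lower number from compound 2 to compound 4 (0.39 log units; beyond the scatter) estimated. For compound 4 the estimate in this assay is 20000 nM, between 3000 nM and 60000 nM.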

Compound 4, half-maximal inhibitory concentration: > 50000 nM
Compound 4: a limit, no number; the forecaster's own chance of this, stated with the estimate: 40%; at least 2.5-fold (0.39 log units) between middle value and limit.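

For the compounds shown here, compound 2 and compound 4 both stand only at a limit of the assay, so no step between them can be read. The compounds shown leave open whether 3-methoxyphenyl and 4-nitrophenyl differ at all in this assay.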